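A Bulkier Amine on the Side Chain

This account rests on a few compounds, and the source may have more. Where it says the series, first, only, none or still open, it means among the compounds named here.

Compound 1 `CN(C)CCCn1c(N)c(-c2nc3ccccc3[nH]2)c2nc(C#N)c(C#N)nc21` and compound 2 `CCN(CC)CCCn1c(N)c(-c2nc3ccccc3[nH]2)c2nc(C#N)c(C#N)nc21` share one core and differ only in the amine at the end of the side chain. In a functional assay on cells (Homo sapiens) for antiproliferative activity, read by MTT assay, with a stated time of 48 h (a lower number here means a stronger inhibitor, a higher number a weaker inhibitor), compound 1 gives 1820 nM, while compound 2 gives 28900 nM. The change diethylamino in place of dimethylamino on a saturated chain carbon, three bonds along the chain from an aromatic nitrogen thus made a step of a 16-fold higher number from compound 1 to compound 2 (1.20 log units; beyond the scatter). Compound 3 `CN(C)CCn1c(N)c(-c2nc3cc(Cl)ccc3[nH]2)c2nc(C#N)c(C#N)nc21` has a different core; how its core differs from that of compound 1 is not broken down here. For compound 3 this assay reports only a limit, > 50000 nM, which is the limit described as the limit of > 50000 nM in this assay, at which 1 of the 3 values shown sits. Compound 4 `CCN(CC)CCn1c(N)c(-c2nc3cc(Cl)ccc3[nH]2)c2nc(C#N)c(C#N)nc21` is not yet measured and differs from compound 3 by diethylamino in place of dimethylamino on a saturated chain carbon, two bonds along the chain from an aromatic nitrogen. This is the same kind of change as from compound 1 to compound 2, though the amine here sits two bonds along the chain from the aromatic nitrogen rather than three. Because the earlier change gave a 16-fold higher number from compound 1 to compound 2 (1.20 log units; beyond the scatter), the step from compound 3 to compound 4 is expected to be a step that the limit leaves unreadable from compound 3 to compound 4. Compound 4 is therefore estimated at 150000 nM, most likely again reported only as a limit.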

Compound 4, half-maximal inhibitory concentration: > 50000 nM
Compound 4: no number, only a limit (the forecaster's own chance of this, stated with the estimate: 90%); the middle value lies beyond the limit too.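

No step can be read from compound 3 to compound 4, since both are reported only as limits in this assay: the limit of > 50000 nM in this assay, at which 2 of the 4 values shown sit.

As far as these compounds go, what stays open is whether diethylamino in place of dimethylamino changes the number at all two bonds along the chain from an aromatic nitrogen.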